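Hydrazone aryl exchange: pyridine to indole on the shared core

The source may report more compounds than this note shows. Statements on the series, on what has been measured and on what is new or still open speak of the compounds shown alone.

Compound 1 `CCCSc1nc(N/N=C/c2cccnc2)c2nnn(Cc3ccccc3)c2n1` carries pyridin-3-yl on the hydrazone carbon. In a functional assay on ECa-109 cells (Homo sapiens) for antiproliferative activity, read by MTT assay, with a stated time of 72 h (on this read-out lower numbers stand for stronger inhibition and higher numbers for weaker inhibition), compound 1 returns only a limit, > 64000 nM, so it stands at the limit of > 64000 nM in this assay, at which 1 of the 2 values shown sits, rather than at a number. Within the data shown here, compound 2 `CCCSc1nc(N/N=C/c2cc(OC)c(OC)c(OC)c2)c2nnn(Cc3ccccc3)c2n1`, the only other member measured in this assay, gives 4060 nM. Among the measured compounds shown here, no step between two measured compounds is available, so there is no measured precedent for the size of an aryl exchange on this core.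

Compound 3 `CCCSc1nc(N/N=C/c2c[nH]c3ccccc23)c2nnn(Cc3ccccc3)c2n1` differs from compound 1 in one place: 1H-indol-3-yl in place of pyridin-3-yl on a carbon with a double bond to nitrogen. With compound 1 at a limit, the step can be judged only as a gain of undetermined size or as none beyond the scatter. A gain is expected here. Compound 3 is estimated at 12000 nM, with a range from 2000 nM to 64000 nM. This corresponds to an expected at least 5.3-fold lower number from compound 1 to compound 3 (0.72 log units; beyond the scatter).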

Compound 3, half-maximal inhibitory concentration: 8690 nM
The estimate for compound 3 lay 1.4-fold (0.14 log units) above the measured number; low and high end bracket the measured number.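

In this assay, the hydrazone carbon now has its first readable step: 1H-indol-3-yl in place of pyridin-3-yl gives an at least 7.3-fold lower number from compound 1 to compound 3 (0.86 log units; beyond the scatter). This position on the shared core therefore responds to the aryl exchange by more than the scatter, and compound 3 gives a number where compound 1 gives only a limit. The size of the step remains a lower bound, since the starting point is a limit and not a number: the limit of > 64000 nM in this assay, at which 1 of the 3 values shown sits.

This single exchange adds a hydrogen-bond donor and a second ring together, so it cannot show which of the two goes with the gain. Going by these compounds, a 1-methyl-1H-indol-3-yl or a naphthalen-2-yl group on the same carbon would separate these two changes, and how far the gain carries over to a core with a longer chain on sulfur also stays open.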